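The compounds below may be only part of what the source reports. "The series", "measured", "known", "first", "only" and "open" are said of these compounds alone.

Two compounds of a shared core carry an amide-linked amino acid methyl ester and have been tested in a functional assay (HSMC cells, Homo sapiens) for antiproliferative activity, with a stated time of 72 h; on this read-out lower numbers stand for stronger inhibition and higher numbers for weaker inhibition. Compound 1, `COC(=O)CNC(=O)c1ccc(OC[C@@H]2COc3ccccc3O2)cc1-c1ccccc1C`, gives 700 nM. Compound 2, `COC(=O)[C@H](CC(C)C)NC(=O)c1ccc(OC[C@H]2COc3ccccc3O2)cc1-c1ccccc1C`, gives 3000 nM, the higher of the two numbers, with compound 1 standing the nearer to it by a margin beyond the usual scatter. The two compounds differ both in the amino acid on the amide and in the drawn configuration of the ring stereocentre, so the measured gap cannot be pinned on either change alone.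

Compound 3, `COC(=O)[C@H](CC(C)C)NC(=O)c1ccc(OC[C@@H]2COc3ccccc3O2)cc1-c1ccccc1C`, is the stereoisomer of compound 2: the two compounds have the same atoms and bonds and differ only in configuration as drawn: 1 of 2 stereo elements differ; a stereocentre at a saturated ring carbon is drawn S in compound 2 and R in compound 3. Its ring carbon now matches the configuration drawn for compound 1. On that basis compound 3 is expected to give a somewhat lower number than compound 2, a step of a 2.5-fold lower number from compound 2 to compound 3 (0.40 log units; beyond the scatter), though a result within the scatter would not be surprising. The estimate for compound 3 is 1200 nM, within a range from 400 nM to 3500 nM.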

Compound 3, half-maximal inhibitory concentration: 5200 nM
The estimate for compound 3 lay 4.3-fold (0.64 log units) below the measured number; measured number above the stated range.
By their numbers in this assay, from the lowest: compound 1; then compounds 2 and 3 (each within the scatter of the next).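

Redrawing the ring stereocentre from S to R gives a 1.7-fold higher number from compound 2 to compound 3 (0.24 log units; within the scatter) in this assay, so the two configurations are not told apart in this isobutyl-bearing pair. With the ring configuration held as drawn, isobutyl in place of hydrogen on a saturated chain carbon bound to an amide-type nitrogen and a carbonyl carbon gives a 7.4-fold higher number from compound 1 to compound 3 (0.87 log units; beyond the scatter), which ties a gap beyond the scatter to that one change. The stereocentre comparison is equally direct, and it rests on a single point: the fact that compounds 2 and 3 differ only in the configuration as drawn.

Going by these compounds, whether a methyl group or a longer chain on that carbon would give a number closer to that of compound 1 remains open, as does the effect of a carboxylic acid in place of the methyl ester. Also open, on these data alone, is whether the ring stereocentre matters when hydrogen stands in place of isobutyl.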